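This account rests on a few compounds, and the source may have more. Where it says the series, first, only, none or still open, it means among the compounds named here.

Measured compounds:
compound 1 `Cc1nnsc1CO/N=C/c1c(C)nn(C)c1Oc1cccc(C(F)(F)F)c1` — 10300 nM
compound 2 `Cc1nnsc1CO/N=C/c1c(C)nn(C)c1Oc1ccc(F)cc1` — 30200 nM
compound 3 `Cc1nnsc1CO/N=C/c1c(C)nn(C)c1Oc1ccccc1OC(F)(F)F` — limit only, > 50000 nM

In a functional assay on HCT-116 cells (Homo sapiens) for inhibition, read by MTT assay, with a stated time of 48 h (on this read-out lower numbers stand for stronger inhibition and higher numbers for weaker inhibition), compound 1 gives 10300 nM. Compound 2 gives 30200 nM in this assay, the highest of the two numbers shown; compound 1 sits nearest, at a lower number, and that gap lies beyond the scatter. For compound 3 this assay returns only a limit, > 50000 nM, not a number (the limit of > 50000 nM in this assay, at which 1 of the 3 values shown sits). No two of these compounds differ in a single place, so no measured step can be drawn from them.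

Compound 4 `Cc1nnsc1CO/N=C/c1c(C)nn(C)c1Oc1cccc(F)c1F` is not yet measured. Relative to compound 2 it carries 2,3-difluorophenyl in place of 4-fluorophenyl on an oxygen on an aromatic ring. The aryl group on that oxygen varies across the whole set and the numbers give no consistent direction, with compound 1 standing at a lower number than compound 2 while the third member reaches no number at all. The expected step from compound 2 to compound 4 is a 1.0-fold lower number from compound 2 to compound 4 (0.00 log units; within the scatter), a shift judged unlikely to exceed the scatter in either direction. Compound 4 is accordingly estimated at 30000 nM, with a range from 10000 nM to 90000 nM.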

Compound 4, half-maximal inhibitory concentration: 6560 nM
Compound 4: the middle estimate sits 4.6-fold (0.66 log units) above what was measured, outside the stated range (below it).
By their numbers in this assay, from the lowest: compounds 4 and 1 (each within the scatter of the next); then compound 2. At a limit, above all of these: compound 3.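

For the compounds shown here, the only single-place step now stands in this assay: 2,3-difluorophenyl in place of 4-fluorophenyl on an oxygen on an aromatic ring gives a 4.6-fold lower number from compound 2 to compound 4 (0.66 log units; beyond the scatter). The aryl group at this place therefore moves the number beyond the scatter, even though the change adds only one fluorine and leaves the shared core untouched. Nothing measured here bears on the cause of this step.

Compound 2 and compound 4 differ both in the number of fluorines and in where they stand, so the contribution of each remains unresolved. Also open, going by these compounds, is how this assay would respond to an amine, a carboxylic acid or a methoxy group on the aryl ring in place of fluorine.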